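Adenosine receptor series: chloro to hydrogen, compound 3 to compound 4

A few compounds are considered here, and "the series" means these few. Any claim that something is new, unique, unknown or untested is made for them only; others in the source may bear on it.

Measured in an assay on CHO cells for displacement of a labelled ligand from adenosine receptor A1 (Homo sapiens), read by scintillation counting, with a stated time of 90 min; on this read-out higher numbers stand for weaker inhibition and lower numbers for stronger inhibition:
Compound 1 `O=C(CCc1ccccc1)Nc1nc2ccccc2c(=O)s1` gives 1050 nM.
Compound 2 `COc1cccc(CCC(=O)Nc2nc3ccccc3c(=O)s2)c1` gives 1370 nM.
Compound 3 `O=C(CCCc1ccccc1)Nc1nc2ccc(Cl)cc2c(=O)s1` gives "not determined" (no result reported), so no result is reported for it.

Compound 3 therefore stands nowhere on the numbers shown: it carries a chloro on the core and a longer chain than compound 1, but without a value it cannot be placed against compound 1 or compound 2. Compound 4 `O=C(CCCc1ccccc1)Nc1nc2ccccc2c(=O)s1` is to be measured in this assay. The change from compound 3 to compound 4 is hydrogen in place of chloro on an aromatic carbon.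

The only measured step, a 1.3-fold higher number from compound 1 to compound 2 (0.12 log units; within the scatter), concerns a methoxy on the phenyl of the chain, a different group at a different place, and so bears on the chloro-to-hydrogen change only as a sign that the series has so far shown little movement. For the measured compounds named here, no measured pair isolates the removal of chloro; the data lack any direct guide. Compound 4 does share its unsubstituted core with compound 1, which gives 1050 nM, the two differing only in chain length.

Given no step that speaks to the change, no direction beyond the scatter is expected in this assay. Compound 4 is estimated at 1200 nM, with a range of 350 nM to 4500 nM, set wide for the missing anchor in compound 3.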

Compound 4, inhibition constant: 2500 nM
Estimate against measurement, compound 4: 2.1-fold (0.32 log units) below; the range from low to high includes it.
By their numbers in this assay, from the lowest: compounds 1, 2 and 4 (each within the scatter of the next, the first and the last beyond it).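

In this assay the step from compound 3 to compound 4 cannot be read: compound 3 has no result, so the loss of chloro from the aromatic carbon still has no measured size or direction. For the compounds shown here, what compound 4 adds lies at the chain instead, where benzyl in place of phenyl on the saturated chain carbon gives a 2.4-fold higher number from compound 1 to compound 4 (0.38 log units; beyond the scatter) and so the first step beyond the scatter, though a modest one, while benzyl in place of 3-methoxyphenyl at that carbon gives a 1.8-fold higher number from compound 2 to compound 4 (0.26 log units; within the scatter) and stays within the scatter. No measurement shown here accounts for either step.

Still open, going by these compounds, is whether chloro on the shared core moves the number at all, and whether a fluoro or an amine on that same aromatic carbon would read any differently from hydrogen. Also open, on these data alone, is whether a longer chain than that of compound 4 would carry the number further in the same direction or leave it within the scatter of compound 4, and whether a carboxylic acid on the terminal phenyl would change that reading.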